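The source may hold more compounds than are shown below. What is called first, only, known or untested is meant among the compounds shown, and "the series" means these compounds.

Series notes. Two members of the series carry a number in a functional assay, tested at 200 ug/mL; on this read-out higher numbers stand for a stronger effect at the one concentration tested and lower numbers for a weaker effect. Compound 1 `COc1cc(Br)c(C2C(C#N)=C(N)OC(c3c[nH]c4ccccc34)=C2C#N)cc1OC` is the higher of the two: in this assay compound 1 gives 24.2%. Compound 2 `N#CC1=C(N)OC(c2c[nH]c3ccccc23)=C(C#N)C1c1ccc(Br)cc1` holds the lowest of the two numbers: in this assay compound 2 gives 10.6%, a result that lies beyond the scatter below compound 1. Compound 1 and compound 2 differ in more than one place, so the pair says nothing about any single change; only the two values themselves are known.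

Compound 3 `CN(C)c1ccc(C2C(C#N)=C(N)OC(c3c[nH]c4ccccc34)=C2C#N)cc1` is not yet measured. It differs from compound 2 in one place: dimethylamino in place of bromo on an aromatic carbon. Within the data shown here, no measured pair shares this change, so the direction of the step rests on no precedent from these compounds. Compound 2 gives the lowest number shown, which leaves more room upward than downward. A small step upward from compound 2 to compound 3 is expected, a number 6.4 percentage points higher from compound 2 to compound 3 (within the scatter), and it may well fall within the scatter. For compound 3 the estimated read-out in this assay is 17%, with a range from 5% to 32%.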

Compound 3, a percentage reported as activity, at one concentration (the size of the read-out at that concentration, not a potency): 20.5%
Beside the measured number, compound 3's estimate is 3.5 percentage points below it; the range from low to high includes it.
By their numbers in this assay, from the lowest: compounds 2, 3 and 1 (each within the scatter of the next, the first and the last beyond it).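

In this assay, among these compounds, the exchange of bromo for dimethylamino on an aromatic carbon, para to a large group, gives the first single-place step that can be read: a number 9.9 percentage points higher from compound 2 to compound 3 (within the scatter) for the 4-bromophenyl to 4-(dimethylamino)phenyl change. At this one position, a group of three heavy atoms carrying one hydrogen-bond acceptor can therefore take the place of a single bromine without a step beyond the scatter, and the step gives no firm direction for the change. No measurement shown bears on the reason for this result.

As far as these compounds go, whether a different group at this place, such as a carboxylic acid, a primary amine or a longer chain on the nitrogen, would move the read-out beyond the scatter remains open. Among the compounds shown here, the value of compound 1 (24.2%) also remains unassigned to any single feature, since compound 1 differs from compound 3 in more than one place and no single-place step connects it to the other compounds.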